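Fluoro for methoxy on the shared core

A few compounds are considered here, and "the series" means these few. Any claim that something is new, unique, unknown or untested is made for them only; others in the source may bear on it.

In a functional assay on HepG2 cells (Homo sapiens) for inhibition, read by MTT assay, with a stated time of 48 h (on this read-out lower numbers stand for stronger inhibition and higher numbers for weaker inhibition), compound 1 (`Cc1ccc(-c2ccnc3c2c(-c2ccccc2)nn3-c2ccccc2)cc1`) gives 10700 nM and compound 2 (`COc1ccc(-c2ccnc3c2c(-c2ccccc2)nn3-c2ccccc2)cc1`) gives 6590 nM, so these two stand level within the scatter. Compound 3 (`Fc1ccc(-c2ccnc3c2c(-c2ccccc2)nn3-c2ccccc2)cc1`), not yet measured, carries fluoro in place of methoxy on an aromatic carbon, para to a large group: fluoro in place of methoxy on an aromatic carbon. Within the data shown here, the only measured step bearing on this change is a 1.6-fold lower number from compound 1 to compound 2 (0.21 log units; within the scatter), a swap of methoxy for methyl at that carbon. On this evidence, no step beyond the scatter is expected in this assay. The expected step is a 1.3-fold higher number from compound 2 to compound 3 (0.11 log units; within the scatter). Compound 3 is estimated at 8500 nM, with an expected range of 4000 nM to 18000 nM.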

Compound 3, half-maximal inhibitory concentration: 1570 nM
Compound 3: middle estimate off by 5.4-fold (0.73 log units), on the high side; the whole stated range lies above it.
By their numbers in this assay, from the lowest: compound 3; then compounds 2 and 1 (each within the scatter of the next).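

In this assay this carbon, para to a large group, proves sensitive to its substituent: the change shows a 4.2-fold lower number from compound 2 to compound 3 (0.62 log units; beyond the scatter) and, against methyl, a 6.8-fold lower number from compound 1 to compound 3 (0.83 log units; beyond the scatter) with both steps beyond the scatter. Methyl and methoxy had stood level, so the earlier pair gave no sign of this. Nothing measured here explains the gain with fluoro.

Whether it is particular to fluoro stays open, since chloro, nitrile, an amine or a plain hydrogen at this carbon are not among the compounds shown. Fluoro at other carbons of this ring also remains untested in the compounds shown.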